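Bromo for methyl on the shared core

A few compounds are considered here, and "the series" means these few. Any claim that something is new, unique, unknown or untested is made for them only; others in the source may bear on it.

In an assay for inhibition of Rho-associated protein kinase 1 (Homo sapiens), read by TR-FRET, with stated times of 5 min and 2 h (on this read-out higher numbers stand for weaker inhibition and lower numbers for stronger inhibition), compound 1 `Cc1c(-c2cn[nH]c2)sc2c1N(C)C(C)(C)NC2=O` gives 44 nM, the highest of the two numbers at hand; nearest is compound 2 `CC(C)C1(C)NC(=O)c2sc(-c3ccncc3)cc2N1`, which in this assay gives 35 nM, a gap within the scatter. Compound 3 `CN1c2c(sc(-c3cn[nH]c3)c2Br)C(=O)NC1(C)C` differs from compound 1 by bromo in place of methyl on an aromatic carbon. Going by the values given here, no measured pair shows this change, so its effect is open; the estimated step of a 1.3-fold lower number from compound 1 to compound 3 (0.10 log units; within the scatter) is expected to stay close to the scatter. For compound 3 the expected value in this assay is 35 nM, within 12 nM to 110 nM.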

Compound 3, half-maximal inhibitory concentration: 22 nM
The estimate for compound 3 lay 1.6-fold (0.20 log units) above the measured number; measured number inside the range.
By their numbers in this assay, from the lowest: compounds 3, 2 and 1 (each within the scatter of the next).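

Going by these compounds alone, on the aromatic carbon of the shared core, bromo in place of methyl gives a 2.0-fold lower number from compound 1 to compound 3 (0.30 log units; within the scatter) in this assay, the first direct reading of this change. The position therefore takes bromo with no step beyond the scatter, although this rests on a single pair. No measurement at hand offers an explanation for this result.

On these data alone, whether an amine, a methoxy group or a carboxylic acid on this carbon would stay within the scatter remains open. Also open, as far as these compounds go, is whether the same exchange reads alike without the 1H-pyrazol-4-yl group.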